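Aryl Swap on the Ring Nitrogen: Compound 4 Expected

A few compounds are considered here, and "the series" means these few. Any claim that something is new, unique, unknown or untested is made for them only; others in the source may bear on it.

Measured compounds:
compound 1, `Cc1ccc(-n2nc(-c3ccc(C(F)(F)F)cc3O)nc2-c2ccccc2O)cc1`: 71.5%
compound 2, `Oc1cc(C(F)(F)F)ccc1-c1nc(-c2ccccc2O)n(-c2ccccc2Cl)n1`: 70.1%
compound 3, `Cc1ccc(-n2nc(-c3ccc(C(F)(F)F)cc3O)nc2-c2ccccc2O)c(C)c1`: 73.7%

In a functional assay on PC-12 cells (Rattus norvegicus) for cytotoxicity, read by MTT assay, with stated times of 2 h and 24 h, tested at 1 uM (a higher number here means a stronger effect of the compound at the concentration tested, a lower number a weaker effect), compound 3 gives 73.7%. Its number is the largest of the three, but the steps of a number 2.2 percentage points higher from compound 1 to compound 3 (within the scatter) and a number 3.6 percentage points higher from compound 2 to compound 3 (within the scatter) are both within the scatter, so compound 3 sits level with the other two. Compound 4, `Oc1cc(C(F)(F)F)ccc1-c1nc(-c2ccccc2O)n(-c2ccc(F)cc2F)n1`, differs from compound 3 as follows: 2,4-difluorophenyl in place of 2,4-dimethylphenyl on an aromatic nitrogen. Two measured steps also exchange the group on the ring nitrogen, a number 1.4 percentage points lower from compound 1 to compound 2 (within the scatter) and a number 3.6 percentage points higher from compound 2 to compound 3 (within the scatter), and both are within the scatter. A step of the same small size is therefore expected here, a number 2.7 percentage points lower from compound 3 to compound 4 (within the scatter), with no direction beyond the scatter. Compound 4 is estimated at 71%, with a range from 61% to 81%.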

Compound 4, a percentage reported as activity, at one concentration (the size of the read-out at that concentration, not a potency): 65.9%
For compound 4 the middle estimate is 5.1 percentage points above the measured one, within the range that was stated.
By their numbers in this assay, from the lowest: compounds 4, 2, 1 and 3 (each within the scatter of the next).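

Among the compounds shown here, with 2,4-difluorophenyl on the aromatic nitrogen, fluorine appears at this position for the first time, and in this assay all three new steps stay within the scatter: a number 7.8 percentage points lower from compound 3 to compound 4 (within the scatter) and a number 4.2 percentage points lower from compound 2 to compound 4 (within the scatter) and a number 5.6 percentage points lower from compound 1 to compound 4 (within the scatter). The four aryl groups carrying methyl, chlorine or fluorine therefore cannot be told apart by this read-out at the concentration tested. No supporting data bear on this result.

Still open, as far as these compounds go, is whether an amine or a carboxylic acid on this aryl ring would give a step beyond the scatter. From the compounds shown here alone, a longer alkyl chain in place of the aryl group on this nitrogen also remains open.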